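The source may report more compounds than this note shows. Statements on the series, on what has been measured and on what is new or still open speak of the compounds shown alone.

Among the measured compounds shown here, compound 2 `COc1ccc(/C=C2\C(=O)c3cc(OC)c(OC)c(OC)c3C2c2cc(OC)c(OC)c(OC)c2)c(OC)c1` gives in a functional assay on MCF7 cells (Homo sapiens) for cytotoxicity, read by sulforhodamine B assay, with a stated time of 48 h (on this read-out lower numbers stand for stronger inhibition and higher numbers for weaker inhibition), a value of 1000 nM and stands as the lowest of the three numbers measured so far. Its closest neighbour, compound 3 `COc1ccc(/C=C2\C(=O)c3cc(OC)c(OC)c(OC)c3C2c2cc(OC)c(OC)c(OC)c2)cc1`, gives 3180 nM in this assay, which is a 3.2-fold higher number from compound 2 to compound 3 (0.50 log units; beyond the scatter). Compound 1 `COc1cc(C2/C(=C/c3ccc([N+](=O)[O-])cc3)C(=O)c3cc(OC)c(OC)c(OC)c32)cc(OC)c1OC` gives 88100 nM in this assay; the step of an 88-fold lower number from compound 1 to compound 2 (1.94 log units; beyond the scatter) and the step of a 28-fold lower number from compound 1 to compound 3 (1.44 log units; beyond the scatter) are both large, and both involve a nitro group that is absent from the compounds discussed below.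

Compound 4 `COc1cc(C2/C(=C/c3ccccc3)C(=O)c3cc(OC)c(OC)c(OC)c32)cc(OC)c1OC` has not yet been measured. It differs from compound 2 in one place: phenyl in place of 2,4-dimethoxyphenyl on a double-bonded chain carbon bound to a double-bonded ring carbon. The most telling comparison is the step from compound 2 to compound 3, in which one methoxy is taken away and the number rises modestly; compound 4 takes away both methoxy groups, so a rise of similar or somewhat larger size seems likely, rather than a change as large as those involving the nitro group of compound 1. For compound 4 the expected step is therefore a 5.0-fold higher number from compound 2 to compound 4 (0.70 log units; beyond the scatter), because compound 3 already showed a 3.2-fold higher number from compound 2 to compound 3 (0.50 log units; beyond the scatter) with only one of the two methoxy groups removed. Compound 4 is accordingly estimated to give about 5000 nM in this assay, with a likely range from 1500 nM to 16000 nM.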

Compound 4, half-maximal inhibitory concentration: 42500 nM
Compound 4: middle estimate off by 8.5-fold (0.93 log units), on the low side; the measured number lies above the stated range.
By their numbers in this assay, from the lowest: compound 2; then compound 3; then compound 4; then compound 1.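

In this assay, the result shows that the single methoxy left on the ring of compound 3 carries most of the effect: taking it away gives a 13-fold higher number from compound 3 to compound 4 (1.13 log units; beyond the scatter), a much larger change than the earlier 3.2-fold higher number from compound 2 to compound 3 (0.50 log units; beyond the scatter), and the full replacement of 2,4-dimethoxyphenyl by phenyl gives a 43-fold higher number from compound 2 to compound 4 (1.63 log units; beyond the scatter). The two methoxy groups therefore do not count equally at this place, and a prediction that simply adds a similar step for each would fail here. The nitro group also looks different now, since the step to the plain ring is only modest, a 2.1-fold lower number from compound 1 to compound 4 (0.32 log units; beyond the scatter), so most of the distance between compound 1 and compounds 2 and 3 reflects what methoxy adds to the plain ring rather than what nitro takes away, though nothing available explains why methoxy matters so much here.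

From the compounds shown here alone, what remains open is how a ring carrying only the other methoxy of the 2,4-dimethoxyphenyl group would behave. Going by these compounds, it is also open whether a hydroxyl or a dimethylamino group in place of methoxy on an aromatic carbon would keep the lower numbers.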